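This account rests on a few compounds, and the source may have more. Where it says the series, first, only, none or still open, it means among the compounds named here.

Within the data shown here, in a functional assay on SMMC-7721 cells (Homo sapiens) for cytotoxicity, read by MTT assay, with a stated time of 48 h (on this read-out lower numbers stand for stronger inhibition and higher numbers for weaker inhibition), compound 2 `CCN(CC)Cc1cc(Cl)cc2c(=O)cc(-c3ccc([N+](=O)[O-])cc3)oc12` gives 2990 nM as the only number so far, so nothing measured stands beside it for ranking. For compound 1 `Cc1cc(Cl)cc2c(=O)cc(-c3ccccc3Cl)oc12` the entry reads "not determined" (no result reported) and offers no comparison. Compound 3 `CCN(CC)Cc1cc(Cl)cc2c(=O)cc(-c3ccccc3Cl)oc12` carries 2-chlorophenyl in place of 4-nitrophenyl on an aromatic carbon next to the ring oxygen 2-chlorophenyl in place of 4-nitrophenyl on an aromatic carbon of the shared core. Among the measured compounds shown here, no measured step shows what this swap does in this assay here, so the expected step of a 1.3-fold higher number from compound 2 to compound 3 (0.13 log units; within the scatter) is small and stays within the usual scatter. For compound 3 the estimated value is 4000 nM with an expected range from 1500 nM to 12000 nM in this measurement.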

Compound 3, half-maximal inhibitory concentration: 810 nM
Compound 3: middle estimate off by 4.9-fold (0.69 log units), on the high side, and the stated range ends above it.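

In this assay the swap of 4-nitrophenyl for 2-chlorophenyl on an aromatic carbon next to the ring oxygen gives a 3.7-fold lower number from compound 2 to compound 3 (0.57 log units; beyond the scatter) and so shows that the group at this position can move the read-out beyond the usual scatter. No measurement shown here explains this step. The nitro group and the ring position of the substituent both differ in this one swap, so the two compounds cannot separate their contributions. A plain phenyl, a 4-chlorophenyl or a 4-methoxyphenyl at this position would help to tell them apart.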